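This account rests on a few compounds, and the source may have more. Where it says the series, first, only, none or still open, it means among the compounds named here.

In a functional assay on PC-3 cells (Homo sapiens) for cytotoxicity, read by colorimetric assay (a higher number here means a weaker inhibitor, a lower number a stronger inhibitor), compound 1 (`O=C(/C=C/c1ccc(CN2C(=O)/C(=C3\Nc4ccccc4\C3=N/O)c3cc(Cl)ccc32)cc1)NO`) gives 60 nM. Compound 2 (`O=C(NO)c1ccc(CN2C(=O)/C(=C3\Nc4ccccc4\C3=N/O)c3cc(Cl)ccc32)cc1`) gives 50 nM, and compound 3 (`O=C(NO)c1ccc(CN2C(=O)/C(=C3\Nc4ccccc4\C3=N/O)c3cc(F)ccc32)cc1`) gives 50 nM. Compound 1 lies within the usual scatter of both of the others, so these three numbers cannot be ranked.

Compound 4 (`O=C(/C=C/c1ccc(CN2C(=O)/C(=C3\Nc4ccccc4\C3=N/O)c3ccccc32)cc1)NO`) differs from compound 1 in one place, with hydrogen in place of chloro on an aromatic carbon.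

The closest evidence is no change at the digits printed from compound 2 to compound 3 (within the scatter), a swap of fluoro in place of chloro on an aromatic carbon at the same place in the shared core. Among the compounds with values here, the only other measured step is a 1.2-fold lower number from compound 1 to compound 2 (0.08 log units; within the scatter), which has hydroxycarbamoyl in place of 2-(hydroxycarbamoyl)ethenyl on an aromatic carbon. It shows that a change elsewhere in the molecule also left the number within the scatter. Within the data shown here, neither step removes the halogen, and no compound lacking one has been measured, so the evidence is indirect. Even so, with the halogen swap in compound 3 at 50 nM, no shift beyond the scatter is expected in this assay, in either direction.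

The expected step is a 1.2-fold higher number from compound 1 to compound 4 (0.07 log units; within the scatter). For compound 4 the estimate is 70 nM, with an expected range from 30 nM to 170 nM.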

Compound 4, half-maximal inhibitory concentration: 50 nM
Beside the measured number, compound 4's estimate is 1.4-fold (0.15 log units) above it, within the range that was stated.
By their numbers in this assay, from the lowest: compounds 2, 3, 4 and 1 (each within the scatter of the next).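

In this assay, hydrogen in place of chloro on an aromatic carbon gives a 1.2-fold lower number from compound 1 to compound 4 (0.08 log units; within the scatter). Until now this place had only seen one halogen swapped for another, from compound 2 to compound 3, so a halogen had been present in every compound shown; compound 4 is the first with none there, and its number still stays within the scatter of compound 1. For this pair, then, the chloro is not required for a number of this size in this cytotoxicity read-out, although no measurement shown here says why the change makes so little difference.

The compounds shown leave open whether this place would accept something other than hydrogen, fluoro or chloro, such as a methoxy group, an amine or a carboxylic acid, with the number again staying within the scatter. They also leave open whether hydrogen at this place would behave the same way in the compounds carrying hydroxycarbamoyl rather than 2-(hydroxycarbamoyl)ethenyl, since the halogen has been removed only from compound 1.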